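This account rests on a few compounds, and the source may have more. Where it says the series, first, only, none or still open, it means among the compounds named here.

In an ADME assay for permeability, using PAMPA, with a stated time of 4 h, at pH 7.4 (on this read-out lower numbers stand for lower permeability and higher numbers for higher permeability), compound 1 `NC(=O)NC/C=C\CN(C[C@H]1Cc2ncccc2CN1)[C@H]1CCCc2cccnc21` gives 2 nm/s as its reading, and compound 2 `c1cnc2c(c1)CN[C@@H](CN(CCCCNC1CCOCC1)[C@H]1CCCc3cccnc31)C2` gives 8 nm/s as the higher of the two numbers in hand. Compound 3 `c1cnc2c(c1)CN[C@@H](CN(CCCC1CCNCC1)[C@H]1CCCc3cccnc31)C2`, not yet measured, differs from compound 2 by piperidin-4-yl in place of ((oxan-4-yl)amino)methyl on a saturated chain carbon, three bonds along the chain from an amine nitrogen on a saturated chain carbon, three bonds along the chain from an amine nitrogen.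

Within the data shown here, only one measured step bears on this change, and it does so indirectly. That step, a 4.0-fold higher number from compound 1 to compound 2 (0.60 log units; beyond the scatter) as a modest move beyond the scatter, alters a group on a saturated chain carbon bound to an amine nitrogen. Compound 2 and compound 3 each carry one six-membered non-aromatic ring with 1 hetero atom, whereas the changed group in compound 1 has no ring. Among the measured compounds shown here, no measured pair isolates the swap made here, so the evidence is thin. The expected step in this assay is therefore small, a 1.3-fold lower number from compound 2 to compound 3 (0.12 log units; within the scatter) and so within the scatter, with only a slight lean towards a lower number. For compound 3 the estimated value is 6 nm/s with an expected range from 3 nm/s to 15 nm/s on repeated measurement.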

Compound 3, apparent permeability: 24 nm/s
The estimate for compound 3 lay 4.0-fold (0.60 log units) below the measured number; measured number outside the range, above it.
By their numbers in this assay, from the lowest: compound 1; then compound 2; then compound 3.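

In this assay, this swap on a saturated chain carbon, three bonds along the chain from an amine nitrogen, keeps one six-membered non-aromatic ring with 1 hetero atom on both sides, yet the number still moves beyond the scatter (a 3.0-fold higher number from compound 2 to compound 3 (0.48 log units; beyond the scatter)). The earlier step from compound 1 to compound 2 also brought in such a ring, so it could not show this: having the ring does not by itself fix the reading, and ((oxan-4-yl)amino)methyl and piperidin-4-yl stand apart despite the same ring count and the same single hydrogen-bond donor. Measured against the ringless group of compound 1, the group in compound 3 now gives a large step (a 12-fold higher number from compound 1 to compound 3 (1.08 log units; beyond the scatter)). Nothing available explains why this swap gives the higher number.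

The swap changes both the hetero atom of the ring and the way the ring is joined to the chain, and the compounds shown do not separate the two. On these data alone, whether oxan-4-yl joined directly through the same chain, or a cyclohexyl group, would read closer to compound 2 or to compound 3 stays open.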